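This account rests on a few compounds, and the source may have more. Where it says the series, first, only, none or still open, it means among the compounds named here.

Measured so far in an assay for inhibition of 15-hydroxyprostaglandin dehydrogenase [NAD(+)] (Homo sapiens), read by fluorescence, with a stated time of 15 min, in the presence of a further agent that is not named here; a higher number here means a weaker inhibitor, a lower number a stronger inhibitor:
Compound 1 `CCCC[S+]([O-])c1sc2nc(-c3nccs3)cc(-c3cccc(CO)c3)c2c1N`: 4.3 nM
Compound 2 `CCCC[S+]([O-])c1sc2nc(-c3nccs3)cc(-c3ccc(C(=O)OC)cc3)c2c1N`: 15.1 nM

Compound 2 gives the higher of the two numbers in this assay. For the measured compounds named here, the only measured step, a 3.5-fold higher number from compound 1 to compound 2 (0.55 log units; beyond the scatter), exchanges one substituted phenyl for another and is modest. Compound 3 `CCCC[S+]([O-])c1sc2nc(-c3nccs3)cc(-c3cnc(C)[nH]3)c2c1N` differs from compound 2 by 2-methyl-1H-imidazol-5-yl in place of 4-(methoxycarbonyl)phenyl on an aromatic carbon. Going by the values given here, no measured step exchanges the phenyl ring itself for a five-membered heteroaryl carrying a hydrogen-bond donor, so the one step offers only a sense of scale, not a direction. For compound 3 a number close to that of compound 2 is expected, with a wide range to either side. Compound 3 is estimated at 12 nM, between 3 nM and 50 nM, an expected step of a 1.3-fold lower number from compound 2 to compound 3 (0.10 log units; within the scatter).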

Compound 3, half-maximal inhibitory concentration: 2.3 nM
Compound 3: middle estimate off by 5.2-fold (0.72 log units), on the high side, outside the stated range (below it).
By their numbers in this assay, from the lowest: compounds 3 and 1 (each within the scatter of the next); then compound 2.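

In this assay, the position opposite the ring nitrogen tolerates a five-membered aromatic ring with 2 hetero atoms: 2-methyl-1H-imidazol-5-yl in place of 4-(methoxycarbonyl)phenyl gives a clear gain (a 6.6-fold lower number from compound 2 to compound 3 (0.82 log units; beyond the scatter)), so a phenyl ring is not required here. Against 3-(hydroxymethyl)phenyl, the same group gives no separable difference (a 1.9-fold lower number from compound 1 to compound 3 (0.27 log units; within the scatter)). No available evidence accounts for either step.

Still open, from the compounds shown here alone, is what an unsubstituted imidazol-5-yl, a pyridyl or a 3-(aminomethyl)phenyl group would give at this position. Going by these compounds, the contribution of the methyl on the imidazole also remains open.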